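Swapping nitro for fluoro on the sulfonyl ring

The source may report more compounds than this note shows. Statements on the series, on what has been measured and on what is new or still open speak of the compounds shown alone.

Measured in a functional assay on MCF7 cells (Homo sapiens) for antiproliferative activity, read by MTT assay, with a stated time of 24 h; on this read-out higher numbers stand for weaker inhibition and lower numbers for stronger inhibition
compound 1 `Cc1ccc(-c2nn(-c3ccccc3)cc2-c2nc3ccccc3n2S(=O)(=O)c2ccc(F)cc2)cc1` gives 5270 nM
compound 2 `COc1ccc(S(=O)(=O)n2c(-c3cn(-c4ccccc4)nc3-c3ccc(C(F)(F)F)cc3)nc3ccccc32)cc1` gives 420 nM
compound 3 `O=[N+]([O-])c1ccc(S(=O)(=O)n2c(-c3cn(-c4ccccc4)nc3-c3ccc(C(F)(F)F)cc3)nc3ccccc32)cc1` gives 1130 nM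

Compound 3 holds the middle of these three numbers, with compound 2 lower and compound 1 higher. Compound 4 `O=S(=O)(c1ccc(F)cc1)n1c(-c2cn(-c3ccccc3)nc2-c2ccc(C(F)(F)F)cc2)nc2ccccc21` is compound 3 with one change (fluoro in place of nitro on an aromatic carbon), fluoro in place of nitro on an aromatic carbon, which turns (4-nitrophenyl)sulfonyl into (4-fluorophenyl)sulfonyl. Among the measured compounds shown here, the only measured step that swaps a group on this ring is a 2.7-fold higher number from compound 2 to compound 3 (0.43 log units; beyond the scatter), a modest one in which nitro took the place of methoxy. Compound 1 also carries (4-fluorophenyl)sulfonyl, but it differs elsewhere in the molecule, so its 5270 nM is only a weak guide. A step of similar or smaller size is therefore expected in this assay, leaning toward a lower number, and it may not clear the usual scatter. The expected step is a 1.4-fold lower number from compound 3 to compound 4 (0.15 log units; within the scatter). The estimate for compound 4 is 800 nM, with an expected range from 280 nM to 2400 nM.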

Compound 4, half-maximal inhibitory concentration: 3120 nM
Beside the measured number, compound 4's estimate is 3.9-fold (0.59 log units) below it; the measured number lies above the stated range.
By their numbers in this assay, from the lowest: compound 2; then compound 3; then compounds 4 and 1 (each within the scatter of the next).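

Changing only the group on this ring moves the number in this assay: nitro to fluoro gives a 2.8-fold higher number from compound 3 to compound 4 (0.44 log units; beyond the scatter) and methoxy to fluoro gives a 7.4-fold higher number from compound 2 to compound 4 (0.87 log units; beyond the scatter) in the same direction. The three groups therefore rank methoxy, nitro, fluoro, from the lowest number to the highest. Elsewhere in the molecule, with fluoro kept on this ring, trifluoromethyl in place of methyl gives a 1.7-fold lower number from compound 1 to compound 4 (0.23 log units; within the scatter) and stays within the usual scatter, so that swap shows no clear effect here, and nothing measured here explains any of these differences.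

As far as these compounds go, whether trifluoromethyl and methyl would also match with methoxy or nitro on this ring remains open. So does how an amine, a carboxylic acid or a plain hydrogen would compare in this position.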